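Shortening the chain toward the pyridinylmethyl amide

The compounds below may be only part of what the source reports. "The series", "measured", "known", "first", "only" and "open" are said of these compounds alone.

Compound 3 `O=C(CCCCCCCc1cn(-c2ccccc2-c2ccccc2)nn1)Nc1cccnc1` stands highest of the three measured compounds in a functional assay on SH-SY5Y cells (Homo sapiens) for cytotoxicity, read by MTT assay, with a stated time of 48 h, tested at 10 uM (a higher number here means a weaker effect of the compound at the concentration tested, a lower number a stronger effect), where compound 3 gives 111%. Its nearest neighbour is compound 1 `O=C(CCCCCCc1cn(-c2ccccc2-c2ccccc2)nn1)NCc1cccnc1`, which in this assay gives 47%, and the furthest is compound 2 `O=C(CCCCCCCc1cn(-c2ccccc2-c2ccccc2)nn1)Nc1ccncc1`, which in this assay gives 32%. The unmeasured compound 4 `O=C(CCCCCc1cn(-c2ccccc2-c2ccccc2)nn1)NCc1cccnc1` differs from compound 3 in one place: a group of 10 heavy atoms (7 carbon, 2 nitrogen, 1 oxygen; one six-membered aromatic ring with 1 hetero atom) in place of a group of 11 heavy atoms (8 carbon, 2 nitrogen, 1 oxygen; one six-membered aromatic ring with 1 hetero atom), on a saturated chain carbon, five bonds along the chain from an aromatic carbon. Among the measured compounds shown here, the step that bears on this change is the one from compound 1 to compound 3, where the same two amide groups are exchanged in the opposite direction: a number 64 percentage points higher from compound 1 to compound 3 (beyond the scatter). For the measured compounds named here, compound 4 therefore carries the amide of compound 1 on a chain that is one carbon shorter, and no measured pair shows what such a shortening does on its own. On that basis the exchange is expected to run in reverse, and compound 4 is expected to give 50% in this assay, with a range from 30% to 75%. This estimate means a large step downward, a number 61 percentage points lower from compound 3 to compound 4 (beyond the scatter), and it rests on compound 1 because of its value 47%.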

Compound 4, a percentage reported as activity, at one concentration (the size of the read-out at that concentration, not a potency): 12.5%
Compound 4: the middle estimate sits 37.5 percentage points above what was measured; the whole stated range lies above it.
By their numbers in this assay, from the lowest: compound 4; then compound 2; then compound 1; then compound 3.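

Among the compounds shown here, the decisive new comparison holds the ((pyridin-3-yl)methyl)carbamoyl group constant and changes only the saturated chain, which no earlier pair could isolate: in this assay, there is a number 34.5 percentage points lower from compound 1 to compound 4 (beyond the scatter), so chain length at this position matters on its own for this amide. The other two steps place compound 4 lowest of the four, with the strongest effect at the concentration tested: there is a number 98.5 percentage points lower from compound 3 to compound 4 (beyond the scatter), and although compound 2 already stood low, there is still a number 19.5 percentage points lower from compound 2 to compound 4 (beyond the scatter), although these two steps change the amide group and the chain together. Nothing measured here accounts for the effect of the shorter chain.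

For the compounds shown here, the single chain-shortening pair does not establish a trend, so it remains open whether a still shorter chain would lower the number further or a longer chain with the same ((pyridin-3-yl)methyl)carbamoyl group would raise it. Also open is how far the result depends on the pyridine ring itself, since neither a phenyl ring in its place nor a carboxylic acid in place of the whole amide group appears among these compounds.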